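A few compounds are considered here, and "the series" means these few. Any claim that something is new, unique, unknown or untested is made for them only; others in the source may bear on it.

In a functional assay on BCG823 cells (Homo sapiens) for antiproliferative activity, read by MTT assay, with a stated time of 48 h (a lower number here means a stronger inhibitor, a higher number a weaker inhibitor), compound 1 `O=c1cc(-c2ccccc2)oc2cc(OCc3ccccc3)c(OCCCN3CCCCC3)c(O)c12` gives 4600 nM, while compound 2 `COc1cc2oc(-c3ccccc3)cc(=O)c2c(O)c1OCCCN1CCCCC1` gives 25300 nM, the higher of the two numbers. Compound 3 `CCN(CC)CCCOc1c(OC)cc2oc(-c3ccccc3)cc(=O)c2c1O` carries diethylamino in place of piperidin-1-yl on a saturated chain carbon, three bonds along the chain from an oxygen on an aromatic ring. Among the compounds with values here, the only measured step, a 5.5-fold higher number from compound 1 to compound 2 (0.74 log units; beyond the scatter), is hydrogen in place of phenyl on a different chain. Within the data shown here, it is a modest step, and it says little about this change, since no measured pair varies the piperidin-1-yl group. A step beyond the scatter is therefore not expected in either direction. The expected step is a 1.0-fold lower number from compound 2 to compound 3 (0.01 log units; within the scatter). For compound 3, the estimated value is 25000 nM, with an expected range of 11000 nM to 55000 nM.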

Compound 3, half-maximal inhibitory concentration: 5700 nM
Estimate against measurement, compound 3: 4.4-fold (0.64 log units) above, outside the stated range (below it).
By their numbers in this assay, from the lowest: compounds 1 and 3 (each within the scatter of the next); then compound 2.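

Within the data shown here, compound 2 and compound 3 give the first measured change at the end of this chain. In this assay, putting diethylamino in place of piperidin-1-yl gives a 4.4-fold lower number from compound 2 to compound 3 (0.65 log units; beyond the scatter). The amine at this chain end therefore affects the result, and here the ringless diethylamino gives the lower number of the pair. No measurement is available to explain this difference. Still open, from the compounds shown here alone, is whether the same change would give a similar step on the core of compound 1, and how a morpholine or dimethylamino group, or a longer chain, would compare.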